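Methylsulfanyl for aminoamino on a second core

This account rests on a few compounds, and the source may have more. Where it says the series, first, only, none or still open, it means among the compounds named here.

Measured compounds:
compound 1, `COc1cccc(-c2nc(NN)n(C)c(=O)c2C#N)c1OC`, in a functional assay on microsomes for inhibition, with a stated time of 1 h (a higher number here means a weaker inhibitor, a lower number a stronger inhibitor), gives 37 ug/mL
compound 2, `COc1cccc(-c2nc(SC)n(C)c(=O)c2C#N)c1OC`, in this assay gives 48 ug/mL
compound 3, `Cn1c(NN)nc(-c2ccccc2Cl)c(C#N)c1=O`, in this assay gives 57 ug/mL

Compounds 1 and 2 share one core and differ by a single change: methylsulfanyl in place of aminoamino on an aromatic carbon. That change gave a 1.3-fold higher number from compound 1 to compound 2 (0.11 log units; within the scatter), a step that stays within the usual scatter of the measurement, so the two numbers cannot be told apart with confidence.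

Compound 3 carries a different core; how it differs from compound 1 is not broken down here. Compound 4, `CSc1nc(-c2ccccc2Cl)c(C#N)c(=O)n1C`, is not yet measured. It stands to compound 3 as compound 2 stands to compound 1: methylsulfanyl in place of aminoamino on an aromatic carbon. The place around the change is described almost identically in both pairs, the one distinction being that in the first pair the site is meta to a large group, while in the second it is meta to a group of 7 heavy atoms; the two changes are therefore the same kind of change rather than the same change.

Because the earlier step of a 1.3-fold higher number from compound 1 to compound 2 (0.11 log units; within the scatter) lay within the scatter, compound 4 is expected to sit close to compound 3, with an estimated step of a 1.2-fold higher number from compound 3 to compound 4 (0.09 log units; within the scatter). For compound 4 the estimate in this assay is 70 ug/mL, with a likely range from 40 ug/mL to 125 ug/mL.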

Compound 4, half-maximal inhibitory concentration: 72 ug/mL
The estimate for compound 4 lay 1.0-fold (0.01 log units) below the measured number; low and high end bracket the measured number.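

On the second core, methylsulfanyl in place of aminoamino gave a 1.3-fold higher number from compound 3 to compound 4 (0.10 log units; within the scatter) in this assay, so this step, like the first, stays within the usual scatter of the measurement. Set beside the step on the core of compound 1, it shows no difference in how the change behaves on the two cores: the same change on two cores in this assay, a 1.3-fold higher number (0.11 log units; within the scatter) from compound 1 to compound 2 and a 1.3-fold higher number (0.10 log units; within the scatter) from compound 3 to compound 4, 1.0-fold (0.01 log units) apart, within the scatter of two such steps. This shows that, in these two pairs, the exchange carried from one core to the other without a step that could be told from scatter, but it does not show that methylsulfanyl and aminoamino truly differ or truly match in this assay, nor does it reach beyond these two cores.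

The compounds shown leave open whether any other group at this site, such as a simple amine, a hydroxyl group or a longer alkylsulfanyl chain, would shift the number beyond the scatter. They also leave open whether the exchange would stay this small on a core that carries a carboxylic acid in place of the cyano group, or on one with a longer chain in place of the ring methyl group.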